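Removing the Iodine from Compound 1: What to Expect

The source may report more compounds than this note shows. Statements on the series, on what has been measured and on what is new or still open speak of the compounds shown alone.

Measured so far in a functional assay on MCF7 cells (Homo sapiens) for cytotoxicity, read by MTT assay, with a stated time of 48 h; on this read-out higher numbers stand for weaker inhibition and lower numbers for stronger inhibition:
Compound 1 `C/C(=N/NC(=S)Nc1ccccc1I)c1ccccn1` gives 4.1 nM.
Compound 2 `CC(=NNC(=S)Nc1ccc(F)cc1)c1ccccn1` gives 1.2 nM.
Compound 3 `CC(=NNC(=S)Nc1ccc([N+](=O)[O-])cc1)c1ccccn1` gives 52 nM.

Among these three numbers, compound 1 stands second highest. Its nearest neighbour is compound 2, whose number is lower by a gap beyond the scatter; compound 3 lies further off, with a number well above that of compound 1. Among the measured compounds shown here, the only single-place step recorded among the measured compounds is a 43-fold higher number from compound 2 to compound 3 (1.64 log units; beyond the scatter), which shows that the group carried on the six-membered aromatic ring of carbon only can move the read-out a long way.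

Compound 4 `C/C(=N/NC(=S)Nc1ccccc1)c1ccccn1` differs from compound 1 by hydrogen in place of iodo on an aromatic carbon. For the measured compounds named here, no measured step strips a group from this ring altogether, and none involves an iodo, so the recorded step bears on the present question only indirectly: it warns that the change could be sizeable, but says nothing about its direction. Compound 1 and compound 2 differ in both the group and where it sits, so their two values cannot separate these influences. A moderate step is therefore expected, more likely toward a higher number than a lower one, estimated as a 1.7-fold higher number from compound 1 to compound 4 (0.23 log units; within the scatter). Compound 4 is expected to show about 7 nM, with a plausible range from 2 nM to 25 nM.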

Compound 4, half-maximal inhibitory concentration: 0.18 nM
Beside the measured number, compound 4's estimate is 39-fold (1.59 log units) above it; the whole stated range lies above it.
By their numbers in this assay, from the lowest: compound 4; then compound 2; then compound 1; then compound 3.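

In this assay, a 23-fold lower number from compound 1 to compound 4 (1.36 log units; beyond the scatter) shows that the iodo, ortho to a large group on the six-membered aromatic ring of carbon only, is far from neutral: taking this single atom away and leaving plain hydrogen gives a much lower number, which on this read-out means stronger inhibition. Among the compounds shown here, the earlier compounds showed only one group exchanged for another, in a 43-fold higher number from compound 2 to compound 3 (1.64 log units; beyond the scatter), whereas this step shows that removing a group from the ring altogether can also produce a large change, and that a ring with no added group can still give a very low number, as compound 4 does at 0.18 nM. Nothing available here accounts for the size or direction of this change.

Going by these compounds, it remains open whether this step reflects iodo in particular or any group at this place, and a chloro, a methyl or an amine on the same carbon would help to separate those two readings. On these data alone, it is also open whether iodo on a different carbon of the ring would give a number close to that of compound 1.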